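This account rests on a few compounds, and the source may have more. Where it says the series, first, only, none or still open, it means among the compounds named here.

Measured so far in a functional assay on HCT-116 cells (Homo sapiens) for antiproliferative activity, read by MTT assay, with a stated time of 48 h; on this read-out lower numbers stand for stronger inhibition and higher numbers for weaker inhibition:
Compound 1 `Cc1cccc(-n2nncc2CN2C(=O)C3(C(C#N)=C(N)Oc4c(N)cc5nc6ccccc6nc5c43)c3ccccc32)c1` gives > 50000 nM, a limit of the assay.
Compound 2 `Cc1ccc(-n2nncc2CN2C(=O)C3(C(C#N)=C(N)Oc4c(N)cc5nc6ccccc6nc5c43)c3ccccc32)cc1C` gives > 50000 nM, a limit of the assay.
Compound 3 `Cc1cc(C)cc(-n2nncc2CN2C(=O)C3(C(C#N)=C(N)Oc4c(N)cc5nc6ccccc6nc5c43)c3ccccc32)c1` gives > 50000 nM, a limit of the assay.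

Compound 3 thus stands at the assay's limit, as the other two do, so the limit of > 50000 nM in this assay, at which 3 of the 3 values shown sit, is all that is known of them. The steps between them, a step that the two limits leave unreadable from compound 1 to compound 2, a step that the two limits leave unreadable from compound 1 to compound 3 and a step that the two limits leave unreadable from compound 2 to compound 3, cannot be read in size. Compound 4 `N#CC1=C(N)Oc2c(N)cc3nc4ccccc4nc3c2C12C(=O)N(Cc1cnnn1-c1ccc(Cl)cc1Cl)c1ccccc12` differs from compound 3 by 2,4-dichlorophenyl in place of 3,5-dimethylphenyl on an aromatic nitrogen. Within the data shown here, the step from compound 2 to compound 3, a swap of one phenyl group for another on the same aromatic nitrogen, is the closest precedent, and it too is unreadable. Among the measured compounds shown here, no measured step therefore tells which direction to expect in this assay. Compound 4 is estimated at 80000 nM, within 20000 nM to 300000 nM, most likely again a limit. That estimate for compound 4 means a step that the limit leaves unreadable from compound 3 to compound 4.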

Compound 4, half-maximal inhibitory concentration: > 50000 nM
Compound 4: a limit, no number; the forecaster's own chance of this, stated with the estimate: 80%; the middle value lies beyond the limit too.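

Compound 4 also gives a limit and not a number, so its steps from compound 1, compound 2 and compound 3 cannot be read. Whether any group on this aromatic nitrogen gives a measurable value in this assay stays open, because all the compounds shown share one limit: the limit of > 50000 nM in this assay, at which 4 of the 4 values shown sit.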